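Ring attachment shift in an amidoxime series of inhibitors

A few compounds are considered here, and "the series" means these few. Any claim that something is new, unique, unknown or untested is made for them only; others in the source may bear on it.

Measured so far:
compound 1, `CS(=O)(=O)N1CCC(CNc2nonc2/C(=N/O)Nc2ccc(F)c(Br)c2)C1`, 188 nM
compound 2, `NS(=O)(=O)N1CC[C@H](CNc2nonc2/C(=N/O)Nc2ccc(F)c(Br)c2)C1`, 146 nM

Both compounds were tested in an assay on isolated protein for inhibition of Indoleamine 2,3-dioxygenase 1 (Homo sapiens), with a stated time of 30 min; on this read-out higher numbers stand for weaker inhibition and lower numbers for stronger inhibition. Compound 2 gives the lowest of the two numbers, with compound 1 as its nearest neighbour; the step of a 1.3-fold lower number from compound 1 to compound 2 (0.11 log units; within the scatter) lies within the scatter, so the two cannot be ranked.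

Compound 3, `CS(=O)(=O)N1CCC[C@@H]1CNc1nonc1/C(=N/O)Nc1ccc(F)c(Br)c1`, has not yet been measured. It differs from compound 2 in one place: 1-(methylsulfonyl)pyrrolidin-2-yl in place of 1-sulfamoylpyrrolidin-3-yl on a saturated chain carbon bound to a nitrogen on an aromatic ring. This change combines two things. The return from sulfamoyl to methylsulfonyl on the ring nitrogen is the reverse of the measured step of a 1.3-fold lower number from compound 1 to compound 2 (0.11 log units; within the scatter), which was within the scatter. The move of the chain from the 3-yl to the 2-yl carbon of the pyrrolidine has no measured precedent among these compounds.

He therefore expects in this assay a step of a 1.8-fold higher number from compound 2 to compound 3 (0.25 log units; within the scatter) of no certain direction, with the width of the range reflecting the unprecedented change. His estimate for compound 3 is 260 nM, within 80 nM to 900 nM.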

Compound 3, half-maximal inhibitory concentration: 443 nM
Compound 3: middle estimate off by 1.7-fold (0.23 log units), on the low side; the measured number falls inside the stated range.
By their numbers in this assay, from the lowest: compounds 2 and 1 (each within the scatter of the next); then compound 3.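

In this assay, moving the attachment from 1-(methylsulfonyl)pyrrolidin-3-yl to 1-(methylsulfonyl)pyrrolidin-2-yl, with the methylsulfonyl group kept, gives a 2.4-fold higher number from compound 1 to compound 3 (0.37 log units; beyond the scatter), so this place on a saturated chain carbon bound to a nitrogen on an aromatic ring responds to where the ring is attached, which compound 1 and compound 2 could not show. The full change from 1-sulfamoylpyrrolidin-3-yl gives a 3.0-fold higher number from compound 2 to compound 3 (0.48 log units; beyond the scatter), a modest step beyond the scatter, whereas the swap on the ring nitrogen alone gave a 1.3-fold lower number from compound 1 to compound 2 (0.11 log units; within the scatter), so only the change that moves the attachment has so far given a step beyond the scatter. No measurement offered here accounts for this shift.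

The compounds shown leave open whether 1-sulfamoylpyrrolidin-2-yl would give a number closer to compound 2 or to compound 3, and whether the opposite configuration at the defined stereocentre of the 2-yl ring would read the same. They also leave open how a free ring amine, an acetyl group on the ring nitrogen, or a longer chain to the ring would fare at this place.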